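This account rests on a few compounds, and the source may have more. Where it says the series, first, only, none or still open, it means among the compounds named here.

Values in an ADME assay on HL-60 cells (Homo sapiens) for cytotoxicity, read by resazurin assay, with a stated time of 72 h (a lower number here means that less compound is needed, a higher number that more compound is needed for the effect), so far:
- compound 1 (`NCCCCNC(=O)Nc1nc2ccc(C(=O)c3ccccc3)cc2[nH]1`) gives > 30000 nM as a limit
- compound 2 (`NCCCC(=O)Nc1nc2ccc(C(=O)c3ccccc3)cc2[nH]1`) gives > 30000 nM as a limit

Compound 2 gives no number and stands at the limit of > 30000 nM in this assay, at which 2 of the 2 values shown sit, with nothing further known. Compound 3 (`NCCCCCCC(=O)Nc1nc2ccc(C(=O)c3ccccc3)cc2[nH]1`) carries 3-aminopropyl in place of amino on a saturated chain carbon, three bonds along the chain from a carbonyl carbon when set against compound 2. Among the measured compounds shown here, the one measured step bearing on this (a step that the two limits leave unreadable from compound 1 to compound 2) also concerns the chain on the carbonyl, but its size cannot be read. No size or direction carries over from it, so no step beyond the scatter is expected in this assay and another limit is the likeliest report. The estimated step (a number no higher from compound 2 to compound 3 (the limit leaves the size open)) is expected to stay within the scatter. For compound 3 the estimate is 30000 nM with 12000 nM to 60000 nM as the expected range.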

Compound 3, half-maximal effective concentration: > 30000 nM
Compound 3: a limit, no number; the forecaster's own chance of this, stated with the estimate: 75%; the middle value lies on the limit itself.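

In this assay compound 3 gives > 30000 nM, a limit and not a number, so no step among compound 1, compound 2 and compound 3 can be read: the limit of > 30000 nM in this assay, at which 3 of the 3 values shown sit.

The compounds shown leave open whether any chain on the carbonyl gives a number rather than a limit in this assay.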